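Sulfonyl for Benzoyl on the Ring Nitrogen

The compounds below may be only part of what the source reports. "The series", "measured", "known", "first", "only" and "open" are said of these compounds alone.

Measured so far:
compound 1 `COc1cc(C2=NNC(c3ccc(Cl)cc3)C2)ccc1O` gives 140000 nM
compound 2 `COc1cc(C2=NN(C(=O)c3ccccc3)C(c3ccc(Cl)cc3)C2)ccc1O` gives 6000000 nM

Going by the values given here, in an assay on isolated protein for inhibition of Amine oxidase [flavin-containing] B (Homo sapiens), read by fluorescence and Amplex Red, with a stated time of 30 min (on this read-out lower numbers stand for stronger inhibition and higher numbers for weaker inhibition), compound 2 holds the highest of the two numbers; the only step recorded, a 43-fold higher number from compound 1 to compound 2 (1.63 log units; beyond the scatter), shows that benzoyl entering for hydrogen on the amine nitrogen in the ring moved the number far beyond the scatter toward weaker inhibition.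

Compound 3 `COc1cc(C2=NN(S(=O)(=O)c3ccc(C)cc3)C(c3ccc(Cl)cc3)C2)ccc1O` differs from compound 2 by (4-methylphenyl)sulfonyl in place of benzoyl on an amine nitrogen in a ring. Among the compounds with values here, no measured step compares benzoyl with another group on that nitrogen, so the earlier step bears on this change only in showing that substitution there is tolerated poorly. With both groups bulky and uncharged, the working expectation is no step beyond the scatter in this assay. Compound 3 is therefore estimated at 6000000 nM, within 1500000 nM to 20000000 nM, a step of no change at the digits printed from compound 2 to compound 3 (within the scatter) from compound 2 that is expected to fall within the scatter.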

Compound 3, inhibition constant: 6000000 nM
Estimate against measurement, compound 3: no gap at the digits printed; low and high end bracket the measured number.
By their numbers in this assay, from the lowest: compound 1; then compounds 2 and 3 (each within the scatter of the next).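

On the amine nitrogen in the ring, (4-methylphenyl)sulfonyl in place of benzoyl gives no change at the digits printed from compound 2 to compound 3 (within the scatter), so this assay does not tell these two groups apart. Against the hydrogen of the parent compound, the same group gives a 43-fold higher number from compound 1 to compound 3 (1.63 log units; beyond the scatter), which matches the benzoyl step and shows that the shift toward weaker inhibition is not confined to benzoyl. No supporting data are at hand to account for this shared shift.

Still open, going by these compounds, is whether acetyl or methyl on that nitrogen, or a chain ending in an amine or a carboxylic acid, would stay close to compound 1 or shift as far as compound 2 and compound 3. Also open, on these data alone, is how other groups in place of the 4-chlorophenyl group would read on the unsubstituted nitrogen.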